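Ethoxycarbonyl for tetrazole on the anilide aryl ring

This account rests on a few compounds, and the source may have more. Where it says the series, first, only, none or still open, it means among the compounds named here.

Compound 1 `CCn1nnc(-c2ccc(NC(=O)CSc3nnc(CNc4ccccc4)n3CC)cc2)n1` is the anchor of this set. In an assay on isolated protein for inhibition of long-chain fatty acid transport protein 1 (Homo sapiens) (a lower number here means a stronger inhibitor, a higher number a weaker inhibitor), compound 1 gives > 1000 nM, which is a limit of the assay and not a number. Two further members share the core. Compound 2 `CCn1c(CNc2ccccc2)nnc1SCc1nc2cc(Cl)ccc2o1` also sits at a limit in this assay, giving > 1000 nM. Going by the values given here, compound 3 `CCC(=O)c1ccc2nc(CSc3nnc(CNc4ccccc4)n3CC)oc2c1` gives 900 nM in this assay, the only number in the set. Among the compounds with values here, the picture is thin: the limit of > 1000 nM in this assay, at which 2 of the 3 values shown sit, and no step between measured compounds can be read.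

Compound 4 `CCOC(=O)c1ccc(NC(=O)CSc2nnc(CNc3ccccc3)n2CC)cc1` is the untested member. Against compound 1 the change is ethoxycarbonyl in place of 2-ethyl-2H-tetrazol-5-yl on an aromatic carbon. With compound 1 itself only a limit, the step in this assay can only be expected to be small, none beyond the scatter, with no direction that the data support. The step that the limit leaves unreadable from compound 1 to compound 4 is therefore an estimate with wide uncertainty. Compound 4 is expected to give about 1500 nM in this assay, within 400 nM to 6000 nM.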

Compound 4, half-maximal inhibitory concentration: 330 nM
Compound 4: middle estimate off by 4.5-fold (0.66 log units), on the high side; measured number below the stated range.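

In this assay, going by these compounds alone, ethoxycarbonyl in place of 2-ethyl-2H-tetrazol-5-yl on an aromatic carbon, para to a large group, gives an at least 3.0-fold lower number from compound 1 to compound 4 (0.48 log units; beyond the scatter), the first readable step in the set. This position therefore responds to the group it carries, and with compound 4 at 330 nM the anilide series now has a measured number. The value of compound 1, > 1000 nM, is a limit of the assay and not a number, so the step gives only a lower bound on its size: the limit of > 1000 nM in this assay, at which 2 of the 4 values shown sit.

Which part of ethoxycarbonyl matters remains open, and a carboxylic acid, a methyl ester or a primary amide at this place would help separate the carbonyl from the ethyl chain. On these data alone, no other step can be read, so whether this change carries over to other members also remains open.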